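The source may hold more compounds than are shown below. What is called first, only, known or untested is meant among the compounds shown, and "the series" means these compounds.

Measured so far in an assay on HEK293 cells for displacement of a labelled ligand from NPC1-like intracellular cholesterol transporter 1 (Homo sapiens); a higher number here means a weaker inhibitor, a lower number a stronger inhibitor:
Compound 1, `CC(C)(C)c1ccc(C(=O)N2CCC3(CC2)C(=O)N(CC(=O)N2CCC(CCO)CC2)CN3c2ccccc2)cc1`, gives 2600 nM.
Compound 2, `CC(C)(C)c1ccc(C(=O)N2CCC3(CC2)C(=O)N(CC(=O)NCCO)CN3c2ccccc2)cc1`, gives 1000 nM.
Compound 3, `CC(C)(C)c1ccc(C(=O)N2CCC3(CC2)C(=O)N(CC(=O)NCCCCO)CN3c2ccccc2)cc1`, gives 19200 nM.

Compound 3 has the highest number of the three, which in this assay means the weakest binding. The steps that lead to it are a 7.4-fold higher number from compound 1 to compound 3 (0.87 log units; beyond the scatter) and a 19-fold higher number from compound 2 to compound 3 (1.28 log units; beyond the scatter); the step of a 2.6-fold lower number from compound 1 to compound 2 (0.41 log units; beyond the scatter) connects the other two compounds. Compound 4, `CC(C)(C)c1ccc(C(=O)N2CCC3(CC2)C(=O)N(CC(=O)NCCCCN)CN3c2ccccc2)cc1`, differs from compound 3 in one place: amino in place of hydroxy on a saturated chain carbon, four bonds along the chain from an amide-type nitrogen. Going by the values given here, none of the measured steps exchanges a hydroxy for an amino; they alter the length of the chain or the kind of amide nitrogen, so they give no direct guide to this exchange. They show only that this part of the molecule responds strongly to change. Among the compounds with values here, with no measured step bearing on it, the expectation for compound 4 in this assay is a number close to that of compound 3, a 1.3-fold lower number from compound 3 to compound 4 (0.11 log units; within the scatter), with wide uncertainty in both directions. Compound 4 is therefore estimated at 15000 nM, in a range from 4000 nM to 60000 nM.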

Compound 4, half-maximal inhibitory concentration: 14500 nM
For compound 4 the middle estimate is 1.0-fold (0.01 log units) above the measured one, within the range that was stated.
By their numbers in this assay, from the lowest: compound 2; then compound 1; then compounds 4 and 3 (each within the scatter of the next).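

In this assay, amino in place of hydroxy on a saturated chain carbon, four bonds along the chain from an amide-type nitrogen, gives a 1.3-fold lower number from compound 3 to compound 4 (0.12 log units; within the scatter) and so does not separate the two end groups on this chain. The amino compound also stays well apart from the others, with a 15-fold higher number from compound 2 to compound 4 (1.16 log units; beyond the scatter) against the shorter hydroxy chain and a 5.6-fold higher number from compound 1 to compound 4 (0.75 log units; beyond the scatter) against the piperidine amide, much as the 4-hydroxybutyl chain of compound 3 did. No measurement available here explains why the exchange leaves the number within the scatter.

Still open, as far as these compounds go, is whether amino would match hydroxy on the shorter chain of compound 2, whose number is the lowest of the four. A 3-hydroxypropyl chain, or a carboxylic acid at the chain end, also remains to be placed in this series.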